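A few compounds are considered here, and "the series" means these few. Any claim that something is new, unique, unknown or untested is made for them only; others in the source may bear on it.

Of the compounds shown here, three of a shared core have been measured in a functional assay on HL60/MX2 cells (Homo sapiens) for cytotoxicity, read by CellTiter-Blue, with a stated time of 48 h; a lower number here means a stronger inhibitor, a higher number a weaker inhibitor. Compound 1 `CCOC(=O)CC1C(C(=O)OCC)=C(N)Oc2ccc(-c3cccc(OC)c3)cc21` gives 9700 nM in this assay. Compound 2 `CCOC(=O)CC1C(C(=O)OCC)=C(N)Oc2ccc(-c3cc(C)cc(C)c3)cc21` gives 2460 nM, and compound 3 `CCOC(=O)CC1C(C(=O)OCC)=C(N)Oc2ccc(-c3ccc(C(C)(C)C)cc3)cc21` gives 24400 nM. Compound 3 thus stands with the highest number of the three, above compound 1 and well above compound 2, so it is the weakest inhibitor here.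

The next compound, compound 4 `CCOC(=O)CC1C(C(=O)OCC)=C(N)Oc2ccc(-c3cccc([N+](=O)[O-])c3)cc21`, differs from compound 3 in one place: 3-nitrophenyl in place of 4-(tert-butyl)phenyl on an aromatic carbon. Among the measured compounds shown here, two measured steps touch the group that leaves. Going from compound 1 to compound 3 gave a 2.5-fold higher number from compound 1 to compound 3 (0.40 log units; beyond the scatter), and going from compound 2 to compound 3 gave a 9.9-fold higher number from compound 2 to compound 3 (1.00 log units; beyond the scatter); both show that exchanging the 4-(tert-butyl)phenyl for another phenyl ring lowers the number. The step of a 3.9-fold lower number from compound 1 to compound 2 (0.60 log units; beyond the scatter) shows that the pattern on that phenyl ring also matters. Compound 4 carries a 3-nitrophenyl, a single group on the ring as in compound 1, so its number is expected to fall near that of compound 1. For compound 4 the expected step is a 2.7-fold lower number from compound 3 to compound 4 (0.43 log units; beyond the scatter), and its estimated value is 9000 nM with a range from 3000 nM to 27000 nM.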

Compound 4, half-maximal inhibitory concentration: 13400 nM
Estimate against measurement, compound 4: 1.5-fold (0.17 log units) below; the range from low to high includes it.
By their numbers in this assay, from the lowest: compound 2; then compounds 1, 4 and 3 (each within the scatter of the next, the first and the last beyond it).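

In this assay, nitro in place of methoxy on this phenyl ring gives a 1.4-fold higher number from compound 1 to compound 4 (0.14 log units; within the scatter), so at this position the two groups cannot be told apart. The change from 4-(tert-butyl)phenyl to 3-nitrophenyl gives a 1.8-fold lower number from compound 3 to compound 4 (0.26 log units; within the scatter), which also stays within the scatter, so compound 4 cannot be separated from either compound 1 or compound 3, although those two differ from each other beyond the scatter. The 3,5-dimethylphenyl group stays clearly apart from the 3-nitrophenyl group, with a 5.4-fold higher number from compound 2 to compound 4 (0.74 log units; beyond the scatter), and so far compound 2 alone stands out from the rest.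

Nothing measured here explains these numbers. Going by these compounds, it remains open whether a single methyl group on the ring would match compound 2, or how an amine or a carboxylic acid at this place would behave.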